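Aryl swap on the anilino nitrogen: outlook for compound 4

The source may report more compounds than this note shows. Statements on the series, on what has been measured and on what is new or still open speak of the compounds shown alone.

In a functional assay on NCI-H226 cells (Homo sapiens) for inhibition, read by MTT assay, with a stated time of 48 h, tested at 10 uM (a higher number here means more inhibition at the concentration tested (going by the name of the read-out), a lower number less inhibition), compound 1 `CCc1ccc(Nc2cc(NC(=O)Nc3c(Cl)cccc3Cl)ncn2)cc1` gives 39.5%, the second highest of three numbers; compound 3 `CC(C)(C)c1ccc(Nc2cc(NC(=O)Nc3c(Cl)cccc3Cl)ncn2)cc1` gives 40% and compound 2 `CC(C)(C)c1cccc(Nc2cc(NC(=O)Nc3c(Cl)cccc3Cl)ncn2)c1` gives 36.5%, both within the scatter of compound 1. Within the data shown here, the one measured step on this aryl group, a number 0.5 percentage points higher from compound 1 to compound 3 (within the scatter), stays inside the scatter. Compound 4 `Cc1cc(F)cc(Nc2cc(NC(=O)Nc3c(Cl)cccc3Cl)ncn2)c1` carries 3-fluoro-5-methylphenyl in place of 4-ethylphenyl on a nitrogen on an aromatic ring. Among the measured compounds shown here, no measured step introduces a fluorine, so the tert-butyl step is the only guide, and it moved nothing beyond the scatter. For compound 4 the expected step is a number 1.5 percentage points lower from compound 1 to compound 4 (within the scatter), with no change beyond the scatter. Compound 4 is therefore estimated at 38%, with a range from 28% to 48%.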

Compound 4, a percentage reported as inhibition, at one concentration (the size of the read-out at that concentration, not a potency): 78.1%
Compound 4: middle estimate off by 40.1 percentage points, on the low side; the whole stated range lies below it.
By their numbers in this assay, from the lowest: compounds 2, 1 and 3 (each within the scatter of the next); then compound 4.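

In this assay this position on the nitrogen on an aromatic ring is not flat, as the tert-butyl step alone suggested: a number 38.6 percentage points higher from compound 1 to compound 4 (beyond the scatter), while a number 0.5 percentage points higher from compound 1 to compound 3 (within the scatter). The 3-fluoro-5-methylphenyl swap changes both the substituents and their placement on the ring, and this single step does not separate the two. No measurement shown here explains the step.

Still open, on these data alone, is whether the fluorine, the methyl or the pair accounts for it. Also open, as far as these compounds go, is whether chlorine or methoxy in place of the fluorine would keep it.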